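This account rests on a few compounds, and the source may have more. Where it says the series, first, only, none or still open, it means among the compounds named here.

Working notes on the series. In a functional assay on HEK293 cells for agonist activity at D(4) dopamine receptor (Homo sapiens), read by FLIPR (on this read-out lower numbers stand for smaller maximal responses and higher numbers for larger maximal responses), compound 1 `Cc1cccc(NC(=O)CN2CCC(c3ccc(O)cc3)CC2)c1` gives 60%. Compound 2 `c1ccc(C2CCN(Cc3nc4ccccc4[nH]3)CC2)nc1` gives 62% in this assay, and compound 3 `COc1cccc(C)c1NC(=O)CN1CCC(c2cccc[n+]2[O-])CC1` gives 56%. Compound 1 thus sits between the other two, and the gaps to both are within the usual scatter, so no ordering among the three can be read from these numbers.

Compound 4 `Cc1cccc(NC(=O)CN2CCC(c3ccccc3C)CC2)c1` has not been measured. It differs from compound 1 as follows: 2-methylphenyl in place of 4-hydroxyphenyl on a saturated ring carbon. Going by the values given here, no measured pair in the set shows a comparable change, so there is no basis for a directional prediction; a step no larger than the scatter, or a modest fall, is expected, with a number 5 percentage points lower from compound 1 to compound 4 (within the scatter). For compound 4 the expected efficacy is 55%, within a range of 35% to 75%.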

Compound 4, largest response reached (reported as efficacy), in percent of the reference or control that the assay uses: 43%
Beside the measured number, compound 4's estimate is 12 percentage points above it, within the range that was stated.
By their numbers in this assay, from the lowest: compound 4; then compounds 3, 1 and 2 (each within the scatter of the next).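

Going by these compounds alone, this is the first step that lies beyond the scatter: in this assay, 2-methylphenyl in place of 4-hydroxyphenyl on a saturated ring carbon gives a number 17 percentage points lower from compound 1 to compound 4 (beyond the scatter). The maximal response therefore depends on which aryl group sits at this position, three ring bonds from the ring nitrogen. Nothing available explains this fall.

Going by these compounds, the change alters both the substituent and its place on the aromatic ring, so the contribution of each stays open. Unsubstituted phenyl, 4-methylphenyl or 2-hydroxyphenyl at this position would separate the two.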